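This account rests on a few compounds, and the source may have more. Where it says the series, first, only, none or still open, it means among the compounds named here.

In a functional assay on CCRF-CEM cells (Homo sapiens) for cytotoxicity, in the absence of a further agent (a lower number here means a stronger inhibitor, a higher number a weaker inhibitor), compound 1 (`Nc1nc(N)c(CCCN(Cc2ccc(NC(CCC(=O)O)C(=O)O)cc2)c2cc(F)c([N+](=O)[O-])cc2[N+](=O)[O-])c(O)n1`) gives 44000 nM. Compound 2 (`Nc1nc(N)c(CCCN(Cc2ccc(NC(CCC(=O)O)C(=O)O)cc2)c2cc(F)c(F)cc2[N+](=O)[O-])c(O)n1`) reads > 100000 nM, which is a limit of the assay. Compound 3 (`Nc1nc(N)c(CCCN(Cc2ccc(NC(CCC(=O)O)C(=O)O)cc2)c2ccc([N+](=O)[O-])c(F)c2F)c(O)n1`) reads > 100000 nM, which is also a limit and not a number. Compound 3 therefore stands at the limit of > 100000 nM in this assay, at which 2 of the 3 values shown sit.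

Compound 4 (`Nc1nc(N)c(CCCN(Cc2ccc(NC(CCC(=O)O)C(=O)O)cc2)c2cc(F)ccc2[N+](=O)[O-])c(O)n1`) has 5-fluoro-2-nitrophenyl in place of 2,3-difluoro-4-nitrophenyl on an amine nitrogen.

Going by the values given here, two measured steps bear on this change. Fluoro in place of nitro on an aromatic carbon gave an at least 2.2-fold higher number from compound 1 to compound 2 (0.35 log units; beyond the scatter), the only step of readable size, and it points toward weaker inhibition. The exchange of aryl groups on the amine nitrogen gave a step that the two limits leave unreadable from compound 2 to compound 3, so it offers no size to carry over. Among the compounds with values here, no measured step shows a gain from a group of this kind, so compound 4 is expected to stay close to the limit in this assay. The estimated change is a number no higher from compound 3 to compound 4 (the limit leaves the size open), and no step beyond the scatter is expected. For compound 4 the estimate is 100000 nM, with an expected range from 40000 nM to 250000 nM.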

Compound 4, half-maximal inhibitory concentration: > 100000 nM
Compound 4 was reported as a limit; the forecaster's own chance of this, stated with the estimate: 65%; the middle value lies on the limit itself.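

Replacing the nitro group with hydrogen gives an at least 2.2-fold higher number from compound 1 to compound 4 (0.35 log units; beyond the scatter), so the loss seen with fluoro at that carbon also appears with hydrogen there. Compound 4 reads as a limit of the assay and not a number, and the steps that reach it from compound 2 and from compound 3 join two limits and cannot be read. Of the aryl groups on the amine nitrogen shown so far, only that of compound 1 gives a value short of the limit in this assay: the limit of > 100000 nM in this assay, at which 3 of the 4 values shown sit.

On these data alone, how compound 2, compound 3 and compound 4 truly rank in this assay stays open, since the limit hides any differences among them. Also open, as far as these compounds go, is whether an amine or a nitrile on that aromatic carbon would lower the number as the nitro group of compound 1 does.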